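A few compounds are considered here, and "the series" means these few. Any claim that something is new, unique, unknown or untested is made for them only; others in the source may bear on it.

Of the compounds shown here, three built on one shared core have been measured in an in vitro functional assay on HEK293-A cells for positive allosteric modulation of metabotropic glutamate receptor 5 (Homo sapiens), read by FLIPR and calcium flux; a higher number here means that more compound is needed for the effect, a lower number that less compound is needed. Compound 1 `Cc1ccc(N2CC(c3nc(-c4cccc(C)c4)no3)CC2=O)cc1` gives 1300 nM. Compound 2 `O=C1CC(c2nc(-c3ccccc3)no2)CN1c1ccc(F)cc1` gives 58 nM. Compound 3 `Cc1ccc(N2CC(c3nc(-c4cccc(F)c4)no3)CC2=O)cc1` gives 1200 nM. On these three numbers compound 3 stands close to compound 1 and far from compound 2, and since compound 2 differs from compound 3 in more than one place, nothing beyond the two values themselves can be read from that gap. Within the data shown here, the only single-place step among the measured compounds, a 1.1-fold lower number from compound 1 to compound 3 (0.03 log units; within the scatter), shows that exchanging a methyl for a fluoro on the outer aromatic ring left the number essentially unchanged.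

Compound 4 `Cc1ccc(N2CC(c3nc(-c4ccccc4)no3)CC2=O)cc1` is the next step from compound 3: hydrogen in place of fluoro on an aromatic carbon. Among the measured compounds shown here, the one measured step that touches this position is a 1.1-fold lower number from compound 1 to compound 3 (0.03 log units; within the scatter), and its size lay within the scatter. For the measured compounds named here, no measured pair swaps fluoro for hydrogen here, so the expectation rests on that single neighbouring step alone. The step expected in this assay is therefore a 1.2-fold lower number from compound 3 to compound 4 (0.08 log units; within the scatter), in other words no change beyond the scatter. Compound 4 is estimated to give 1000 nM in this assay, with a likely range from 350 nM to 2800 nM.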

Compound 4, half-maximal effective concentration: 384 nM
Beside the measured number, compound 4's estimate is 2.6-fold (0.42 log units) above it; low and high end bracket the measured number.
By their numbers in this assay, from the lowest: compound 2; then compound 4; then compounds 3 and 1 (each within the scatter of the next).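

In this assay, the place that seemed indifferent turns out to matter: hydrogen in place of fluoro gives a 3.1-fold lower number from compound 3 to compound 4 (0.49 log units; beyond the scatter), and hydrogen in place of methyl gives a 3.4-fold lower number from compound 1 to compound 4 (0.53 log units; beyond the scatter). The earlier compounds shown here showed only that methyl and fluoro at this place could not be told apart; now both are seen to give a higher number than the plain phenyl, so having either group there, rather than hydrogen, is what shows up in the read-out. At a different place in the molecule, methyl in place of fluoro gives a 6.6-fold higher number from compound 2 to compound 4 (0.82 log units; beyond the scatter), so an exchange that moved nothing at the first place does move the number at the second, and the size of this exchange depends on where it is made: the same change on two cores in this assay, a 1.1-fold lower number (0.03 log units; within the scatter) from compound 1 to compound 3 and a 6.6-fold lower number (0.82 log units; beyond the scatter) from compound 4 to compound 2, 6.1-fold (0.79 log units) apart, beyond the scatter of two such steps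

The compounds shown carry only hydrogen, methyl or fluoro at this place, so it remains open whether a methoxy group, a nitrile or an amine there would also give a higher number than hydrogen. As far as these compounds go, it also remains open whether going from 3-fluorophenyl to phenyl would give a similar step on the core of compound 2, which already carries fluoro at the second place.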